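Dechlorination of a tetraacetoxy core and its cytotoxicity

A few compounds are considered here, and "the series" means these few. Any claim that something is new, unique, unknown or untested is made for them only; others in the source may bear on it.

In a functional assay on HeLa cells (Homo sapiens) for cytotoxicity, read by XTT assay, with a stated time of 24 h (a higher number here means a weaker inhibitor, a lower number a stronger inhibitor), compound 1 `CC(=O)Oc1cc(OC(C)=O)c2c(OC(C)=O)cc(C)c(Cl)c2c1OC(C)=O` gives 52900 nM, the highest of the three numbers recorded. Compound 2 `COc1cc(C)cc2c1C(=O)C=CC2=O` gives 21100 nM in this assay, and compound 3 `COc1cc(C)c(Cl)c2c1C(=O)C=CC2=O` gives 19100 nM. Compound 3 and compound 2 differ in one place, (hydrogen in place of chloro on an aromatic carbon), and that change made a step of a 1.1-fold higher number from compound 3 to compound 2 (0.04 log units; within the scatter). How the core of compound 1 differs from the core of compound 3 is not broken down here. Compound 4 `CC(=O)Oc1cc(OC(C)=O)c2c(OC(C)=O)cc(C)cc2c1OC(C)=O` carries the same kind of change as compound 2 carries relative to compound 3, namely (hydrogen in place of chloro on an aromatic carbon); here the place is para to an acetoxy group rather than para to a methoxy group. Resting on the step from compound 3 to compound 2, the step from compound 1 to compound 4 in this assay is expected to be a 1.1-fold higher number from compound 1 to compound 4 (0.04 log units; within the scatter). Compound 4 is therefore estimated at 58000 nM, between 30000 nM and 115000 nM.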

Compound 4, half-maximal inhibitory concentration: 22400 nM
Compound 4: middle estimate off by 2.6-fold (0.41 log units), on the high side; measured number below the stated range.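

In this assay hydrogen in place of chloro gives a 2.4-fold lower number from compound 1 to compound 4 (0.37 log units; beyond the scatter) on the core of compound 1, whereas the same change gives a 1.1-fold higher number from compound 3 to compound 2 (0.04 log units; within the scatter) on the core of compound 3. Among these compounds, with only two pairs, this neither proves that the change carries over unchanged from one core to the other nor shows that the cores respond differently. The step on the core of compound 1 lies beyond the scatter on its own, but the two steps cannot be told apart: the same change on two cores in this assay, a 1.1-fold higher number (0.04 log units; within the scatter) from compound 3 to compound 2 and a 2.4-fold lower number (0.37 log units; beyond the scatter) from compound 1 to compound 4, 2.6-fold (0.42 log units) apart, within the scatter of two such steps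

The compounds shown compare only hydrogen and chloro at this place, so the effect of bromo, methoxy or an amine there remains open. Also open, from the compounds shown here alone, is whether the step would hold with free hydroxyl groups in place of the acetoxy groups.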